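A few compounds are considered here, and "the series" means these few. Any claim that something is new, unique, unknown or untested is made for them only; others in the source may bear on it.

Measured compounds:
- compound 1, `CC(C)(N)C(=O)N[C@H](COCc1ccccc1)c1nnnn1Cc1ccc(NS(C)(=O)=O)cc1`: 259 nM
- compound 2, `CC(C)(N)C(=O)N[C@H](COCc1ccccc1)c1nnn(Cc2ccc(NS(C)(=O)=O)cc2)n1`: 986 nM
- compound 3, `CC(C)(N)C(=O)N[C@H](COCc1ccccc1)c1nnn(CCCc2ccccc2NS(C)(=O)=O)n1`: 107 nM

All three values come from a functional assay on H4 cells for agonist activity at growth hormone secretagogue receptor type 1 (Homo sapiens), read by FLIPR; a lower number here means that less compound is needed, a higher number that more compound is needed for the effect. Within this small set, compound 1 stands second highest: compound 3 gives the nearest number, lower than that of compound 1 by a gap beyond the usual scatter, and compound 2 gives the furthest number, higher than that of compound 1 by a gap that is also beyond the scatter. The three compounds share the same core and differ in how the methanesulfonamide-bearing ring is attached, so the figures show that this attachment matters, though no single exchange among them has been measured as a step.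

The unmeasured compound 4, `CC(C)(N)C(=O)N[C@H](COCc1ccccc1)c1nnnn1CCC(=O)NCc1ccccc1`, keeps the core of compound 1 and changes only one piece: (benzylcarbamoyl)methyl in place of 4-(methanesulfonamido)phenyl on a saturated chain carbon bound to an aromatic nitrogen. Among the measured compounds shown here, no measured pair shows what such an exchange does, since every measured compound carries the same 4-(methanesulfonamido)phenyl group.

For compound 4 the step from compound 1 is expected to be a modest rise, a 1.9-fold higher number from compound 1 to compound 4 (0.29 log units; within the scatter), with a direction that is uncertain. In this assay compound 4 is estimated at 500 nM, within a range from 120 nM to 2500 nM.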

Compound 4, half-maximal effective concentration: 51 nM
The estimate for compound 4 lay 9.8-fold (0.99 log units) above the measured number, outside the stated range (below it).
By their numbers in this assay, from the lowest: compound 4; then compound 3; then compound 1; then compound 2.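

In this assay, among the compounds shown here, the exchange of 4-(methanesulfonamido)phenyl for (benzylcarbamoyl)methyl on a saturated chain carbon bound to an aromatic nitrogen gives a 5.1-fold lower number from compound 1 to compound 4 (0.71 log units; beyond the scatter), so a low number at this position does not require the methanesulfonamide group carried by all the earlier compounds. Both groups hold 11 heavy atoms, one six-membered aromatic ring of carbon only and 1 hydrogen-bond donor, whereas the entering group has no sulfur and 1 hydrogen-bond acceptor against 2, which shows that this position tolerates a real change in the group's make-up. No supporting measurement accompanies this result to account for the size of the step.

The compounds shown do not separate the contributions of the carbonyl, the amide hydrogen and the benzyl ring within (benzylcarbamoyl)methyl, so it remains unclear which of these parts the lower number depends on. From the compounds shown here alone, it is also open how a carboxylic acid, an amine or a longer chain would behave at this place, and whether the same exchange would lower the number on the core of compound 2.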